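The source may report more compounds than this note shows. Statements on the series, on what has been measured and on what is new or still open speak of the compounds shown alone.

Measured compounds:
Compound 1 `CCCNc1cc(-c2ccccc2)nc2cc(OC)cc(OC)c12` gives 970 nM in a functional assay on HCT-116 cells (Homo sapiens) for inhibition, read by MTT assay, with a stated time of 72 h; on this read-out lower numbers stand for stronger inhibition and higher numbers for weaker inhibition.
Compound 2 `COc1cc(OC)c2c(-n3ccnc3)cc(-c3ccccc3)nc2c1` gives 42400 nM in this assay.
Compound 3 `COc1cc(OC)c2c(N3CCCCC3)cc(-c3ccccc3)nc2c1` gives 32000 nM in this assay.

Compound 2 stands at the highest number of the three. Its nearest neighbour is compound 3, separated by a 1.3-fold lower number from compound 2 to compound 3 (0.12 log units; within the scatter), while compound 1 lies far away, separated by a 44-fold higher number from compound 1 to compound 2 (1.64 log units; beyond the scatter).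

The next compound, compound 4 `COc1cc(OC)c2c(NC3CCCCC3)cc(-c3ccccc3)nc2c1`, has not yet been measured in this assay. It arises from compound 2 by a single change: cyclohexylamino in place of 1H-imidazol-1-yl on an aromatic carbon. Compound 4 thus carries, like compound 1 with its propylamino, a group joined through an amine nitrogen that carries a hydrogen, whereas compound 2 and compound 3 carry ring nitrogens without one.

Going by the values given here, two measured steps bear on this change. The step of a 44-fold higher number from compound 1 to compound 2 (1.64 log units; beyond the scatter) shows how much weaker the inhibition became when propylamino gave way to the imidazolyl group, and the step of a 33-fold higher number from compound 1 to compound 3 (1.52 log units; beyond the scatter) shows a comparable loss when piperidinyl took that place. The reverse direction, a return to an amine bearing a hydrogen, is therefore expected to yield a large step to a lower number, a 17-fold lower number from compound 2 to compound 4 (1.23 log units; beyond the scatter), landing near the value of compound 1, 970 nM. Compound 4 is accordingly estimated at 2500 nM, within a range of 600 nM to 12000 nM.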

Compound 4, half-maximal inhibitory concentration: 3820 nM
The estimate for compound 4 lay 1.5-fold (0.18 log units) below the measured number, and the stated range covers the measured number.
By their numbers in this assay, from the lowest: compound 1; then compound 4; then compounds 3 and 2 (each within the scatter of the next).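

In this assay, the change to cyclohexylamino brings a large drop, an 11-fold lower number from compound 2 to compound 4 (1.05 log units; beyond the scatter), and a similar one against the piperidinyl compound, an 8.4-fold lower number from compound 3 to compound 4 (0.92 log units; beyond the scatter), so a second amine bearing a hydrogen now stands at this position on the aromatic carbon opposite the ring nitrogen. Among these four compounds, both amines bearing a hydrogen give lower numbers than both groups joined through a ring nitrogen, and no compound shown goes against this, yet the group on that nitrogen also counts, with a 3.9-fold higher number from compound 1 to compound 4 (0.60 log units; beyond the scatter) when cyclohexyl replaces propyl. Nothing measured here gives a reason for either difference.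

As far as these compounds go, it stays open whether the gap between the propyl and cyclohexyl compounds follows the ring itself or the number of carbons, which a straight hexylamino chain at this place would help to separate. From the compounds shown here alone, it also stays open how much depends on the hydrogen on the nitrogen, since the groups without one are all ring nitrogens, and a methyl(propyl)amino group would put that question directly.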